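Swapping chloro for hydrogen when every value is a limit

The source may hold more compounds than are shown below. What is called first, only, known or untested is meant among the compounds shown, and "the series" means these compounds.

Three compounds with a shared core were tested in a functional assay on PBMC cells (Homo sapiens) for inhibition, read by ELISA, with a stated time of 18 h; a lower number here means a stronger inhibitor, a higher number a weaker inhibitor. Compound 1 `CCCCSC(=S)C1=C(Nc2ccc(Cl)cc2Cl)CC(C)(C)CC1=O` gives only a limit of the assay, > 20 ug/mL. Compound 3 `CCCCSC(=S)C1=C(Nc2ccc(Cl)cc2)CC(C)(C)CC1=O` differs from compound 1 by hydrogen in place of chloro on an aromatic carbon. In this assay compound 3 also gives only a limit, > 20 ug/mL. The step between them, a step that the two limits leave unreadable from compound 1 to compound 3, therefore has no readable size.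

Compound 2 `CC(=O)OC[C@H]1O[C@@H](SC(=S)C2=C(Nc3ccc(Cl)cc3Cl)CC(C)(C)CC2=O)[C@H](OC(C)=O)[C@@H](OC(C)=O)[C@@H]1OC(C)=O` has a different core, and the difference between the two cores is not broken down here. In this assay compound 2 gives only a limit, > 20 ug/mL.

Compound 4 `CC(=O)OC[C@H]1O[C@@H](SC(=S)C2=C(Nc3ccc(Cl)cc3)CC(C)(C)CC2=O)[C@H](OC(C)=O)[C@@H](OC(C)=O)[C@@H]1OC(C)=O` has not yet been measured. It differs from compound 2 by hydrogen in place of chloro on an aromatic carbon, the same change as that from compound 1 to compound 3. Going by the values given here, since (the limit of > 20 ug/mL in this assay, at which 3 of the 3 values shown sit), no measured step gives the size of this change. The step expected from compound 2 to compound 4 is estimated as a step that the limit leaves unreadable from compound 2 to compound 4, resting on a step that the two limits leave unreadable from compound 1 to compound 3 and on (the limit of > 20 ug/mL in this assay, at which 3 of the 3 values shown sit). On this basis compound 4 is expected to give about 30 ug/mL, estimated between 8 ug/mL and 120 ug/mL.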

Compound 4, half-maximal inhibitory concentration: 3.5 ug/mL
Estimate against measurement, compound 4: 8.6-fold (0.93 log units) above, and the stated range ends above it.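

On the core of compound 2, going from 2,4-dichlorophenyl to 4-chlorophenyl gives an at least 5.7-fold lower number from compound 2 to compound 4 (0.75 log units; beyond the scatter) in this assay, so here the change clearly comes with stronger inhibition. On the core of compound 1 the same change shows no such result, as compound 3 gives only a limit, > 20 ug/mL. This suggests that the gain does not carry over to a measurable value on every core, but it does not show how large the change is on the core of compound 1, and a single readable pair cannot establish a rule for the series: the limit of > 20 ug/mL in this assay, at which 3 of the 4 values shown sit.

As far as these compounds go, it remains open whether a fluoro or a methoxy group in place of the lost chloro would behave like hydrogen, and what the remaining chloro contributes. Also open, from the compounds shown here alone, is whether compound 4 needs its acetyl groups, or whether free hydroxyl groups in their place would give similar inhibition.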